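N-aryl para substituent swap in the sulfonamide series

The source may report more compounds than this note shows. Statements on the series, on what has been measured and on what is new or still open speak of the compounds shown alone.

Measured compounds in a functional assay on A549 cells (Homo sapiens) for antiproliferative activity, read by MTT assay, with a stated time of 72 h; on this read-out lower numbers stand for stronger inhibition and higher numbers for weaker inhibition:
compound 1 `O=C1COc2ccc(-c3cnc(Cl)c(NS(=O)(=O)c4ccc(F)cc4)c3)cc2N1C1CCCCC1` gives 37900 nM
compound 2 `O=C1COc2ccc(-c3cnc(Cl)c(NS(=O)(=O)c4ccc(F)cc4)c3)cc2N1c1ccc(Cl)cc1` gives 21600 nM
compound 3 `COc1ncc(-c2ccc3c(c2)N(c2ccc(Cl)cc2)C(=O)CO3)cc1NS(=O)(=O)c1ccc(F)cc1` gives 8350 nM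

Compound 2 holds the second highest of the three numbers in this assay; its nearest neighbour is compound 1, with a 1.8-fold lower number from compound 1 to compound 2 (0.24 log units; within the scatter), and its furthest is compound 3, with a 2.6-fold lower number from compound 2 to compound 3 (0.41 log units; beyond the scatter).

Compound 4 `COc1ccc(N2C(=O)COc3ccc(-c4cnc(Cl)c(NS(=O)(=O)c5ccc(F)cc5)c4)cc32)cc1` is not yet measured. It differs from compound 2 by methoxy in place of chloro on an aromatic carbon, the group sitting on an aromatic carbon of a six-membered aromatic ring of carbon only, para to a large group. Within the data shown here, two measured steps bear on this. The step from compound 1 to compound 2 changes the same nitrogen substituent and is a 1.8-fold lower number from compound 1 to compound 2 (0.24 log units; within the scatter), within the scatter. The step from compound 2 to compound 3 is the same group exchange but on another aromatic carbon, and is a 2.6-fold lower number from compound 2 to compound 3 (0.41 log units; beyond the scatter), modest. A step of at most that size, downward or none beyond the scatter, is therefore expected here: a 1.4-fold lower number from compound 2 to compound 4 (0.16 log units; within the scatter). Compound 4 is estimated at 15000 nM, within 6000 nM to 40000 nM.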

Compound 4, half-maximal inhibitory concentration: 30400 nM
Compound 4: the middle estimate sits 2.0-fold (0.31 log units) below what was measured; the range from low to high includes it.
By their numbers in this assay, from the lowest: compound 3; then compounds 2, 4 and 1 (each within the scatter of the next).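

In this assay the exchange of 4-chlorophenyl for 4-methoxyphenyl on the ring nitrogen gives a 1.4-fold higher number from compound 2 to compound 4 (0.15 log units; within the scatter) and so does not register at this position, while the same group exchange on another aromatic carbon gives a 2.6-fold lower number from compound 2 to compound 3 (0.41 log units; beyond the scatter) and does register there. The step of a 1.2-fold lower number from compound 1 to compound 4 (0.10 log units; within the scatter) sits alongside a 1.8-fold lower number from compound 1 to compound 2 (0.24 log units; within the scatter) and shows that neither aryl group separates from cyclohexyl on this nitrogen in this assay. Nothing measured here accounts for the exchange counting on one aromatic carbon and not on the other.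

Open, going by these compounds, is whether an amine or a carboxylic acid on this aromatic carbon, or a longer chain such as ethoxy, would move the number beyond the scatter. Among these compounds, also open is whether methoxy on both aromatic carbons would track the single exchanges.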